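A few compounds are considered here, and "the series" means these few. Any claim that something is new, unique, unknown or untested is made for them only; others in the source may bear on it.

Measured compounds:
compound 1 `Nc1cc(N)c2nc(-c3ccccc3)c(NCc3ccc(F)cc3)nc2c1` — 23400 nM
compound 2 `COc1ccc(CNc2nc3cc(N)cc(N)c3nc2-c2ccccc2)cc1` — 18200 nM

In a functional assay on M14 cells (Homo sapiens) for inhibition, read by sulforhodamine B assay, with a stated time of 48 h (on this read-out lower numbers stand for stronger inhibition of growth and higher numbers for weaker inhibition of growth), compound 1 gives 23400 nM, and compound 2 gives 18200 nM. Within the data shown here, the two numbers lie within the scatter of one another, the only measured step being a 1.3-fold lower number from compound 1 to compound 2 (0.11 log units; within the scatter), so compound 1 cannot be set apart from compound 2 on these data.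

Compound 3 `Nc1cc(N)c2nc(-c3ccccc3)c(Sc3ccc(Cl)c(Cl)c3)nc2c1` has not yet been measured. It differs from compound 1 in one place: (3,4-dichlorophenyl)sulfanyl in place of (4-fluorobenzyl)amino on an aromatic carbon. Among the measured compounds shown here, the one measured step, from compound 1 to compound 2, touches only the far end of the (4-fluorobenzyl)amino group and stayed within the scatter; no measured pair shows what happens when that whole group gives way to (3,4-dichlorophenyl)sulfanyl. The data therefore give no direction for this assay here, and the expectation is a step of no settled sign, with a wide range.

Compound 3 is estimated to give 20000 nM, with a range from 5000 nM to 80000 nM, which would be expected to mean a 1.2-fold lower number from compound 1 to compound 3 (0.07 log units; within the scatter).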

Compound 3, concentration for 50% growth inhibition: 32400 nM
Compound 3: middle estimate off by 1.6-fold (0.21 log units), on the low side; low and high end bracket the measured number.
By their numbers in this assay, from the lowest: compounds 2, 1 and 3 (each within the scatter of the next).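

In this assay, putting (3,4-dichlorophenyl)sulfanyl in place of the whole (4-fluorobenzyl)amino group gives a 1.4-fold higher number from compound 1 to compound 3 (0.14 log units; within the scatter). Among these compounds, the earlier pair touched only the far end of the group, whereas this exchange replaces everything attached to the aromatic carbon next to the ring nitrogen: the nitrogen link gives way to sulfur, the hydrogen-bond donor of the leaving group has no counterpart in the entering group, and two chlorines enter where there was one fluorine, yet compound 1 and compound 3 still cannot be told apart on this read-out. No measurement at hand bears on the reason for this result.

The compounds shown leave open whether any group at this position would carry the number beyond the scatter, for instance a piperazine, a carboxylic acid or a longer alkyl chain on the linking nitrogen or sulfur. They also leave open whether the same exchange would read alike with something other than the phenyl group on the neighbouring carbon, or without the amino groups on the shared core.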